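A few compounds are considered here, and "the series" means these few. Any claim that something is new, unique, unknown or untested is made for them only; others in the source may bear on it.

Measured compounds:
compound 1, `Cc1cc(Nc2cc(-c3ccccc3)[nH]n2)n2nc(SCc3c(Cl)cccc3Cl)nc2n1`, 3230 nM
compound 2, `Cc1ccc(Cn2ccc(Nc3cc(C)nc4nc(SCc5ccc(Br)cc5)nn34)n2)cc1`, 11300 nM

Of the compounds shown here, two have been measured in a functional assay on MCF7 cells (Homo sapiens) for inhibition, read by MTT assay, with a stated time of 72 h; on this read-out higher numbers stand for weaker inhibition and lower numbers for stronger inhibition. Compound 1 gives 3230 nM, and compound 2 gives 11300 nM. Of the two numbers, compound 1 stands lower, and the gap between compound 1 and compound 2 is beyond the usual scatter, so compound 1 is the stronger inhibitor of the pair in this assay. The two structures differ in several places at once, so no single change can be read from their values.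

The next compound, compound 3, `CCCSc1nc2nc(C)cc(Nc3cc(-c4ccccc4)[nH]n3)n2n1`, differs from compound 1 in one place: ethyl in place of 2,6-dichlorophenyl on a saturated chain carbon bound to a sulfur. The group that leaves is a ring bearing two chlorines, the group that enters is a short chain, and the rest of the core is unchanged. Among the compounds with values here, nothing among the measured compounds shows what such a change does in this assay, so any expectation rests on the change itself. A loss of inhibition is expected, with the step from a 2.8-fold higher number from compound 1 to compound 3 (0.45 log units; beyond the scatter) pointing toward a higher number. Compound 3 is thus estimated at 9000 nM, with a range from 2500 nM to 35000 nM.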

Compound 3, half-maximal inhibitory concentration: > 50000 nM
Compound 3 ended at the assay's limit; the forecaster's own chance of this, stated with the estimate: 15%; at least 5.5-fold (0.74 log units) between middle value and limit.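

In this assay, putting ethyl in place of 2,6-dichlorophenyl on a saturated chain carbon bound to a sulfur gives an at least 15-fold higher number from compound 1 to compound 3 (1.18 log units; beyond the scatter), a large step and the first at this position that can be read as a single change. It shows that, in this pair, inhibition depends strongly on the 2,6-dichlorobenzyl group on the sulfur, and that a propyl group there does not preserve it. Compound 3 gives > 50000 nM, which is a limit of the assay and not a number, so the step has a lower bound but no known upper end: the limit of > 50000 nM in this assay, at which 1 of the 3 values shown sits.

On these data alone, what stays open is whether the loss follows from removing the ring itself or only its two chlorines, a question that an unsubstituted benzyl group at this place would help separate. As far as these compounds go, it is equally open how a cyclohexylmethyl group or a longer chain such as hexyl would read here, and whether the same change would have a similar effect with the other substituents of compound 2.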